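Fluoro to chloro among compounds known only by limits

The source may report more compounds than this note shows. Statements on the series, on what has been measured and on what is new or still open speak of the compounds shown alone.

Of the compounds shown here, three built on one shared core have been measured: compound 1 (`COc1cc2ncnc(Nc3cc(O)[nH]n3)c2cc1OC`), compound 2 (`COc1cc2ncnc(Nc3cc(-c4ccccc4)[nH]n3)c2cc1OC`) and compound 3 (`COc1cc2ncnc(Nc3cc(-c4ccc(F)cc4)[nH]n3)c2cc1OC`). In a functional assay on MDA-MB-231 cells (Homo sapiens) for cytotoxicity, read by MTT assay (on this read-out higher numbers stand for weaker inhibition and lower numbers for stronger inhibition), compound 1 gives < 100000 nM as a limit and not a number. Compound 2 gives < 100000 nM as a limit as well. Compound 3 gives < 100000 nM as a limit too, so it has no numeric place among the others. The whole set shows the limit of < 100000 nM in this assay, at which 3 of the 3 values shown sit, and nothing finer.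

Compound 4 (`COc1cc2ncnc(Nc3cc(-c4ccc(Cl)cc4)[nH]n3)c2cc1OC`) differs from compound 3 in one place, by chloro in place of fluoro on an aromatic carbon with chloro in place of fluoro on an aromatic carbon, para to a large group. The closest measured change, fluoro in place of hydrogen on an aromatic carbon, is a step that the two limits leave unreadable from compound 2 to compound 3 and gives no size or direction. The other two, a step that the two limits leave unreadable from compound 1 to compound 2 and a step that the two limits leave unreadable from compound 1 to compound 3 (both replacing hydroxy), give none either. No step beyond the scatter is therefore expected in this assay in either direction, though little supports this expectation. The estimated change is a step that the limit leaves unreadable from compound 3 to compound 4 and should be read only as a rough guide. For compound 4 the estimated value is 30000 nM with an expected range of 5000 nM to 100000 nM and a limit in place of a number remains the likelier report.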

Compound 4, half-maximal inhibitory concentration: < 100000 nM
Compound 4: a limit, no number; the forecaster's own chance of this, stated with the estimate: 75%; the middle value does not contradict the limit.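

In this assay compound 4 gives < 100000 nM as a limit and not a number. Within the data shown here, no step among compound 1, compound 2, compound 3 and compound 4 can be read, since all of them rest on a single limit: the limit of < 100000 nM in this assay, at which 4 of the 4 values shown sit. The compounds shown leave open what numeric value any of the four has and whether changing the group on the shared core alters it at all.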